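This account rests on a few compounds, and the source may have more. Where it says the series, first, only, none or still open, it means among the compounds named here.

Measured so far in a physicochemical assay for solubility, at pH 1.1; on this read-out lower numbers stand for lower solubility and higher numbers for higher solubility

- compound 1 `CCCN(Cc1ccc(OCCN2C(=O)CCC2=O)c(C)c1)C(CC(=O)O)c1ccc(Cl)cc1` gives 3000000 nM
- compound 2 `CCCN(Cc1ccc(OCCn2c(=O)ccn(C)c2=O)c(OC)c1)C(CC(=O)O)c1ccc(Cl)cc1` gives 3000000 nM
- compound 3 `COc1cc(CN(CC(C)C)C(CC(=O)O)c2ccc(Cl)cc2)ccc1OCCN1C(=O)CCC1=O` gives 3000000 nM

Compound 3 (3000000 nM) stands level with compound 1 and compound 2, all three lying within the scatter. For the measured compounds named here, no measured pair differs in one place only, so no single change has been read directly.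

Compound 4 `COc1cc(CN(CC(C)C)C(CC(=O)O)c2ccc(Cl)c(F)c2)ccc1OCCN1C(=O)CCC1=O` follows from compound 3 by the change fluoro in place of hydrogen on an aromatic carbon and has fluoro in place of hydrogen on an aromatic carbon, ortho to a chloro group. The 4-chlorophenyl thus becomes 4-chloro-3-fluorophenyl.

Set against compound 3, compound 2 differs in more than one place and still gives 3000000 nM and so no move beyond the scatter is expected in this assay for this one replacement. The estimated step of no change at the digits printed from compound 3 to compound 4 (within the scatter) stays within the scatter, with no direction expected. The estimated value for compound 4 is 3000000 nM with an expected range from 1500000 nM to 3500000 nM (not yet measured).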

Compound 4, solubility: 3000000 nM
For compound 4 middle estimate and measured number coincide at the digits printed, and the stated range covers the measured number.
By their numbers in this assay, from the lowest: compounds 1, 2, 3 and 4 (each within the scatter of the next).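

In this assay, for the compounds shown here, fluoro in place of hydrogen on an aromatic carbon, ortho to a chloro group, gives no change at the digits printed from compound 3 to compound 4 (within the scatter), the only step in this set read from a pair that differs in one place. Turning 4-chlorophenyl into 4-chloro-3-fluorophenyl therefore leaves this read-out unmoved for this pair, which the earlier comparisons, each differing in more than one place, could not show. No measurement shown here offers an explanation for this result.

Open, from the compounds shown here alone, is whether a larger group on the same aromatic carbon, such as trifluoromethyl or an amine, would also stay level with compound 3. Also open, going by these compounds, is whether the same fluoro replacement gives the same result on compound 1 and compound 2, and whether a nitrile in place of the chloro group would move the read-out.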